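This account rests on a few compounds, and the source may have more. Where it says the series, first, only, none or still open, it means among the compounds named here.

Compound 3, `Nc1cc(N)c2nc(-c3ccccc3)c(Sc3ccc(F)cc3)nc2c1`, is one of three compounds tested in a functional assay on U-251 cells (Homo sapiens) for inhibition, read by sulforhodamine B assay, with a stated time of 48 h; a higher number here means a weaker inhibitor of growth, a lower number a stronger inhibitor of growth. In this assay compound 3 gives 31600 nM. Compound 1, `Nc1cc(N)c2nc(-c3ccccc3)c(Oc3ccc(Cl)c(Cl)c3)nc2c1`, gives 31600 nM in this assay, and the step of no change at the digits printed from compound 1 to compound 3 (within the scatter) shows that the two stand level within the usual scatter. Compound 2, `CCOC(=O)[C@H](CCC(=O)O)NC(=O)c1ccc(Sc2nc3cc(N)cc(N)c3nc2-c2ccccc2)cc1`, is reported in this assay only as a limit, < 100000 nM, and not as a number. So compound 3 stands level with compound 1, and beyond that the only further information is the limit of < 100000 nM in this assay, at which 1 of the 3 values shown sits.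

Compound 4, `Nc1cc(N)c2nc(-c3ccccc3)c(Oc3ccc(F)cc3)nc2c1`, has not yet been measured. It differs from compound 3 in a single place: 4-fluorophenoxy in place of (4-fluorophenyl)sulfanyl on an aromatic carbon. Among the measured compounds shown here, only one measured step bears on this. That step, no change at the digits printed from compound 1 to compound 3 (within the scatter), put (4-fluorophenyl)sulfanyl in place of 3,4-dichlorophenoxy, a larger change than the one now considered, and it moved the number not at all within the scatter. A smaller change of the same kind, 4-fluorophenoxy in place of (4-fluorophenyl)sulfanyl, is therefore expected to give a step of about no change at the digits printed from compound 3 to compound 4 (within the scatter) in this assay, that is, none beyond the scatter. Compound 4 is estimated to give about 31600 nM in this assay, with a range from 14000 nM to 71000 nM.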

Compound 4, concentration for total growth inhibition: 79400 nM
Estimate against measurement, compound 4: 2.5-fold (0.40 log units) below, outside the stated range (above it).
By their numbers in this assay, from the lowest: compounds 1 and 3 (each within the scatter of the next); then compound 4.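

In this assay, keeping the 4-fluorophenyl ring and changing only the atom that joins it to the aromatic carbon next to the ring nitrogen, from sulfur to oxygen, gives a 2.5-fold higher number from compound 3 to compound 4 (0.40 log units; beyond the scatter), so this swap is not silent even though the leaving and entering groups have the same count of heavy atoms. Keeping the oxygen link and putting 4-fluorophenyl in place of 3,4-dichlorophenyl gives a 2.5-fold higher number from compound 1 to compound 4 (0.40 log units; beyond the scatter), so the substituents on that ring count here as well. The level standing of compound 1 and compound 3 therefore did not show that this position is indifferent to what sits on it, since that pair differs in both the linking atom and the ring substituents, and each of those changes moves the number when made alone in the steps to compound 4.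

Nothing shown gives a reason for either step. Still open, going by these compounds, are whether sulfur and oxygen would differ in the same way with a 3,4-dichlorophenyl ring, and how an amine link, or a short alkyl chain in place of the whole aryl group, would behave at this position.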